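This account rests on a few compounds, and the source may have more. Where it says the series, first, only, none or still open, it means among the compounds named here.

Measured compounds in a functional assay on NCI-H1975 cells (Homo sapiens) for antiproliferative activity, read by MTT assay, with a stated time of 72 h; on this read-out higher numbers stand for weaker inhibition and lower numbers for stronger inhibition:
compound 1 `CC/C=C\C(=O)Nc1cc(Nc2ncc(C#N)c(-c3cn(C)c4ccccc34)n2)c(OC)cc1N(C)CCN(C)C` gives 1150 nM
compound 2 `CC/C=C\C(=O)Nc1cc(Nc2nccc(-c3cn(C)c4ccc(F)cc34)n2)c(OC)cc1N(C)CCN(C)C` gives 2600 nM
compound 3 `C=CC(=O)Nc1cc(Nc2ncc(C#N)c(-c3cn(C)c4ccc(F)cc34)n2)c(OC)cc1N(C)CCN(C)C` gives 11400 nM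

Among these three numbers compound 3 stands highest; the gaps down to compound 2 and to compound 1 both lie beyond the usual scatter, so compound 3 is the weakest inhibitor of the three shown.

Compound 4 `CC/C=C\C(=O)Nc1cc(Nc2ncc(C#N)c(-c3cn(C)c4ccc(F)cc34)n2)c(OC)cc1N(C)CCN(C)C` is not yet measured. It differs from compound 3 in one place only: but-1-en-1-yl in place of vinyl on a carbonyl carbon. Among the compounds with values here, no pair of measured compounds isolates this change, so no measured step can be quoted for it; compounds 1 and 2, which both carry the but-1-en-1-yl group, give lower numbers than compound 3, but each also differs from compound 3 elsewhere.

In this assay the step from compound 3 to compound 4 is expected to run downward, to a lower number, by an amount beyond the scatter, a 3.3-fold lower number from compound 3 to compound 4 (0.51 log units; beyond the scatter). For compound 4 the estimate is 3500 nM, within 1200 nM to 10000 nM.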

Compound 4, half-maximal inhibitory concentration: 10200 nM
Beside the measured number, compound 4's estimate is 2.9-fold (0.46 log units) below it; the measured number lies above the stated range.
By their numbers in this assay, from the lowest: compound 1; then compound 2; then compounds 4 and 3 (each within the scatter of the next).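

In this assay, with the rest of the structure held, but-1-en-1-yl in place of vinyl on a carbonyl carbon gives (a 1.1-fold lower number from compound 3 to compound 4 (0.05 log units; within the scatter)), so this pair does not separate the two groups. With but-1-en-1-yl held, cyano in place of hydrogen on an aromatic carbon gives (a 3.9-fold higher number from compound 2 to compound 4 (0.59 log units; beyond the scatter)). Fluoro in place of hydrogen on an aromatic carbon gives (an 8.9-fold higher number from compound 1 to compound 4 (0.95 log units; beyond the scatter)), also with but-1-en-1-yl held.

Going by these compounds, whether a longer chain or an amine in place of vinyl on a carbonyl carbon would give a step beyond the scatter stays open. Nothing available accounts for any of these steps.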